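Compound 2 to compound 3: a change of aryl group

The compounds below may be only part of what the source reports. "The series", "measured", "known", "first", "only" and "open" are said of these compounds alone.

In a toxicity assay on HUVEC cells (Homo sapiens) for inhibition (on this read-out lower numbers stand for stronger inhibition of growth and higher numbers for weaker inhibition of growth), compound 1 (`Cc1nc(-c2ccccc2)c(C(=O)N2CCN(c3cccc(Cl)c3)CC2)o1`) gives 0.463 ug/mL and compound 2 (`COc1cc(OC)cc(N2CCN(C(=O)c3oc(C)nc3-c3ccccc3)CC2)c1`) gives 0.319 ug/mL. Within the data shown here, compound 2 therefore stands level with compound 1, the only other measured member of the series, as the two numbers lie within the scatter of each other.

Compound 3 (`Cc1nc(-c2ccccc2)c(C(=O)N2CCN(c3ccccc3)CC2)o1`) has phenyl in place of 3,5-dimethoxyphenyl on an amine nitrogen in a ring. Among the measured compounds shown here, one measured step bears on this change, at the same place on the shared core: a 1.5-fold lower number from compound 1 to compound 2 (0.16 log units; within the scatter). That step exchanged 3-chlorophenyl for 3,5-dimethoxyphenyl and stayed within the scatter. For the measured compounds named here, no measured compound carries the plain phenyl, so the evidence is indirect and rests on a single pair.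

Going by the values given here, with that small step as the only guide, no change beyond the scatter is expected. The estimate is a 1.3-fold higher number from compound 2 to compound 3 (0.10 log units; within the scatter), a step expected to stay within the scatter. For compound 3 the expected value is 0.4 ug/mL, with an estimated range of 0.18 ug/mL to 0.9 ug/mL.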

Compound 3, concentration for 50% growth inhibition: 9.63 ug/mL
Estimate against measurement, compound 3: 24-fold (1.38 log units) below; measured number outside the range, above it.
By their numbers in this assay, from the lowest: compounds 2 and 1 (each within the scatter of the next); then compound 3.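

The aryl group on the amine nitrogen in the ring proves to be a sensitive position in this assay: exchanging 3-chlorophenyl for phenyl gives a 21-fold higher number from compound 1 to compound 3 (1.32 log units; beyond the scatter), and exchanging 3,5-dimethoxyphenyl for phenyl gives a 30-fold higher number from compound 2 to compound 3 (1.48 log units; beyond the scatter). The two substituted phenyl groups stand level with each other despite carrying different groups, so among these three compounds the large change appears only with the unsubstituted phenyl, and no compound shown goes against this. Among these compounds, the earlier pair could show only that one substituted ring can replace another, whereas these steps show that the loss of the chloro or of both methoxy groups matters far more than the choice between them, although no measurement on hand accounts for the size of either step.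

Still open, as far as these compounds go, is whether the low numbers depend on chloro or methoxy specifically, or whether a methyl, a fluoro or a single methoxy on the phenyl would give the same result. Also open, from the compounds shown here alone, is how a pyridyl or a saturated cyclohexyl group would behave on the same nitrogen, and whether the steps seen here carry over when the methyl or phenyl on the rest of the shared core is changed.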